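Dimethylamino in place of methylsulfanyl on the shared core

This account rests on a few compounds, and the source may have more. Where it says the series, first, only, none or still open, it means among the compounds named here.

Compound 1 `CN(C)c1ncnc2c1c(-c1ccoc1)cn2[C@@H]1O[C@H](CO)[C@@H](O)[C@H]1O` in a functional assay on A549 cells (Homo sapiens), read by MTT assay, with a stated time of 72 h (on this read-out higher numbers stand for weaker inhibition and lower numbers for stronger inhibition), gives > 20000 nM, which is a limit of the assay and not a number. Compound 2 `CNc1ncnc2c1c(-c1cccs1)cn2[C@@H]1O[C@H](CO)[C@@H](O)[C@H]1O` gives > 20000 nM in this assay, again a limit. Compound 3 `CSc1ncnc2c1c(-c1cccs1)cn2[C@@H]1O[C@H](CO)[C@@H](O)[C@H]1O` gives > 20000 nM in this assay, also a limit. Within the data shown here, the one single-point step measured so far, a step that the two limits leave unreadable from compound 2 to compound 3, cannot be read, and the series as a whole is summed up by the limit of > 20000 nM in this assay, at which 3 of the 3 values shown sit.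

Compound 4 `CN(C)c1ncnc2c1c(-c1cccs1)cn2[C@@H]1O[C@H](CO)[C@@H](O)[C@H]1O` differs from compound 3 by dimethylamino in place of methylsulfanyl on an aromatic carbon. Among the measured compounds shown here, no readable step bears on this change; the only measured step touching the same position is the unreadable one above. Compound 1 carries the same dimethylamino group on an otherwise different core and gives a limit as well. Compound 4 is therefore expected to sit at 30000 nM, within 12000 nM to 100000 nM, most probably reported again only as a limit. The step that the limit leaves unreadable from compound 3 to compound 4 is thus expected to be unreadable rather than a true change.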

Compound 4, half-maximal inhibitory concentration: > 20000 nM
Compound 4 ended at the assay's limit (the forecaster's own chance of this, stated with the estimate: 85%); the middle value is on the limit's open side.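

In this assay compound 4 gives > 20000 nM, which is a limit of the assay. No new step can be read from compound 1, compound 2 or compound 3 to compound 4. The compounds shown leave open whether any of these changes alters inhibition at all: the limit of > 20000 nM in this assay, at which 4 of the 4 values shown sit.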